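A New Aromatic Ring on the Carbonyl Carbon

This account rests on a few compounds, and the source may have more. Where it says the series, first, only, none or still open, it means among the compounds named here.

In a functional assay on MDA-MB-231 cells (Homo sapiens) for inhibition, read by colorimetric assay and sulforhodamine B assay, with a stated time of 48 h (a higher number here means a weaker inhibitor of growth, a lower number a stronger inhibitor of growth), compound 1 (`CCCCCCCCCCCC[C@@H](O)[C@H]1CC[C@H]([C@H](O)CCCCCCCCCCNC(=O)c2cccs2)O1`) gives 2570 nM and compound 2 (`CCCCCCCCCCCC[C@@H](O)[C@H]1CC[C@H]([C@H](O)CCCCCCCCCCNC(=O)c2ccco2)O1`) gives 100000 nM while compound 3 (`CCCCCCCCCCCC[C@@H](O)[C@H]1CC[C@H]([C@H](O)CCCCCCCCCCNC(=O)c2ccsc2)O1`) gives 4470 nM as its read-out. Its place is set by two steps: a 1.7-fold higher number from compound 1 to compound 3 (0.24 log units; within the scatter) lies within the scatter, and a 22-fold lower number from compound 2 to compound 3 (1.35 log units; beyond the scatter) lies beyond it, so it sits level with the thiophen-2-yl compound and far from the furan-2-yl one. Compound 4 (`CCCCCCCCCCCC[C@@H](O)[C@H]1CC[C@H]([C@H](O)CCCCCCCCCCNC(=O)c2ccnn2C)O1`) carries 1-methyl-1H-pyrazol-5-yl in place of thiophen-3-yl on a carbonyl carbon and so loses the sulfur. Among the measured compounds shown here, the one measured step that removes sulfur is a 39-fold higher number from compound 1 to compound 2 (1.59 log units; beyond the scatter) and it is large, yet its incoming group differs from this one, so a smaller upward step is expected in this assay (a 3.4-fold higher number from compound 3 to compound 4 (0.53 log units; beyond the scatter)). Compound 4 is expected near 15000 nM (estimated range 3000 nM to 80000 nM).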

Compound 4, concentration for 50% growth inhibition: 8510 nM
Compound 4: middle estimate off by 1.8-fold (0.25 log units), on the high side; measured number inside the range.
By their numbers in this assay, from the lowest: compounds 1, 3 and 4 (each within the scatter of the next, the first and the last beyond it); then compound 2.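

Sulfur is not required on this carbonyl carbon: the change to 1-methyl-1H-pyrazol-5-yl, with two nitrogens and no sulfur, gives a 1.9-fold higher number from compound 3 to compound 4 (0.28 log units; within the scatter), though against the thiophen-2-yl ring it gives a 3.3-fold higher number from compound 1 to compound 4 (0.52 log units; beyond the scatter). Losing sulfur therefore does not always bring the large loss seen with furan-2-yl, as a 12-fold lower number from compound 2 to compound 4 (1.07 log units; beyond the scatter) shows among the two sulfur-free rings. Nothing here explains why those two rings differ so widely. Still open, going by these compounds, is how a phenyl group or a ring-bound dimethylamino group would compare on this carbonyl carbon.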